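Hydroxyl to ketone on the side chain of compound 1

The source may report more compounds than this note shows. Statements on the series, on what has been measured and on what is new or still open speak of the compounds shown alone.

Measured so far:
compound 1 `C[C@H](O)[C@@H](CCc1ccc(C(F)(F)F)cc1)n1cnc2c(N)ncnc21`: 5.2 nM
compound 2 `C[C@H](O)[C@@H](CSc1ccccc1)n1cnc2c(N)ncnc21`: 135 nM

Within the data shown here, both compounds have been measured in an assay on isolated protein for inhibition of adenosine deaminase (Bos taurus), with a stated time of 5 min; a lower number here means a stronger inhibitor, a higher number a weaker inhibitor. Compound 1 gives 5.2 nM and stands lowest of the two numbers. Compound 2 gives 135 nM, a gap to compound 1 that lies beyond the scatter; compound 2 differs from compound 1 in more than one place, so its number says nothing about any single change.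

Compound 3 `CC(=O)[C@@H](CCc1ccc(C(F)(F)F)cc1)n1cnc2c(N)ncnc21` is not yet measured. It differs from compound 1 by acetyl in place of 1-hydroxyethyl on a saturated chain carbon bound to an aromatic nitrogen and a saturated chain carbon. The hydroxyl and the stereocentre of that group are lost, the acceptor remains. Among the measured compounds shown here, no pair of measured compounds shows this change, so nothing here fixes its size. The expectation is a weaker inhibitor: a step of a 12-fold higher number from compound 1 to compound 3 (1.06 log units; beyond the scatter) is estimated, beyond the scatter, resting only on compound 1 and its 5.2 nM as the starting point. For compound 3 the estimate in this assay is 60 nM, with a range from 15 nM to 300 nM.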

Compound 3, inhibition constant: "not active" (no number reported)
No number was reported for compound 3; there is nothing to compare the estimate with.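

In this assay, among these compounds, compound 3 is reported as "not active" with no number, so no step from compound 1 to compound 3 can be read. No evidence on hand bears on this result. The compounds shown leave open how far acetyl in place of 1-hydroxyethyl moves the number, and whether the missing hydroxyl or the lost stereocentre matters more.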